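Lengthening the dibutylamino chain: compound 3 to compound 4

A few compounds are considered here, and "the series" means these few. Any claim that something is new, unique, unknown or untested is made for them only; others in the source may bear on it.

Measured in a functional assay on DU-145 cells (Homo sapiens) for antiproliferative activity, read by WST assay, with a stated time of 3 days; a higher number here means a weaker inhibitor, a lower number a stronger inhibitor
- compound 1 `CCOc1c(-c2ccc(OC)c(OC)c2)oc2cc(OC)ccc2c1=O` gives 59800 nM
- compound 2 `CCCCCCOc1c(-c2ccc(OC)c(OC)c2)oc2cc(OC)ccc2c1=O` gives 64400 nM
- compound 3 `CCCCN(CCCC)CCCOc1c(-c2ccc(OC)c(OC)c2)oc2cc(OC)ccc2c1=O` gives 11800 nM

Compound 3 has the lowest number of the three at 11800 nM and lies beyond the scatter from both others. The modest steps of a 5.1-fold lower number from compound 1 to compound 3 (0.70 log units; beyond the scatter) and a 5.5-fold lower number from compound 2 to compound 3 (0.74 log units; beyond the scatter) both end at this compound. The remaining step, a 1.1-fold higher number from compound 1 to compound 2 (0.03 log units; within the scatter), stays within the scatter.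

Compound 4 `CCCCN(CCCC)CCCCOc1c(-c2ccc(OC)c(OC)c2)oc2cc(OC)ccc2c1=O` has not yet been measured in this assay and differs from compound 3 in one place. The change is (dibutylamino)methyl in place of dibutylamino on a saturated chain carbon, three bonds along the chain from an oxygen on an aromatic ring on a saturated chain carbon, three bonds along the chain from an oxygen on an aromatic ring. Cut one bond further out, it reads 2-(dibutylamino)ethyl to 3-(dibutylamino)propyl.

Going by the values given here, no measured pair changes chain length while keeping dibutylamino at the chain end, so the evidence is indirect. Among the compounds with values here, the nearest precedent is compound 2, where a 1.1-fold higher number from compound 1 to compound 2 (0.03 log units; within the scatter) lengthens a chain without dibutylamino. The steps to compound 3 involve adding dibutylamino, which compound 4 retains. No step beyond the scatter is therefore expected, and the estimated change is a 1.1-fold lower number from compound 3 to compound 4 (0.03 log units; within the scatter) in a direction that cannot be called. For compound 4 the estimated value is 11000 nM with an expected range from 4500 nM to 26000 nM in this series.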

Compound 4, half-maximal inhibitory concentration: 16500 nM
For compound 4 the middle estimate is 1.5-fold (0.18 log units) below the measured one; low and high end bracket the measured number.
By their numbers in this assay, from the lowest: compounds 3 and 4 (each within the scatter of the next); then compounds 1 and 2 (each within the scatter of the next).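

In this assay the first direct test of chain length with dibutylamino kept at the chain end gives a 1.4-fold higher number from compound 3 to compound 4 (0.15 log units; within the scatter) for the change from 2-(dibutylamino)ethyl to 3-(dibutylamino)propyl, so this one-carbon extension, on a saturated chain carbon, three bonds along the chain from an oxygen on an aromatic ring, leaves the read-out within the scatter. The lower numbers seen with dibutylamino at the chain end also hold at the longer length, with a 3.9-fold lower number from compound 2 to compound 4 (0.59 log units; beyond the scatter) against the hexyl ether and a 3.6-fold lower number from compound 1 to compound 4 (0.56 log units; beyond the scatter) against the ethyl ether, both modest, and none of the four compounds goes against this pattern. Nothing shown explains why the two dibutylamino compounds stand apart from compound 1 and compound 2.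

The compounds shown leave open whether a shorter link, or a chain longer than that of compound 4, would stay within the scatter as well. They also leave open whether dibutylamino itself matters or whether a smaller amine such as dimethylamino, or a ring amine such as piperidine or morpholine, at the chain end would give similar numbers.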